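A Chlorophenyl Swap Awaits Its Growth Inhibition Number

This account rests on a few compounds, and the source may have more. Where it says the series, first, only, none or still open, it means among the compounds named here.

Measured so far in a functional assay on MDA-MB-231 cells (Homo sapiens) for cytotoxicity, read by sulforhodamine B assay, with a stated time of 72 h; a higher number here means a weaker inhibitor of growth, a lower number a stronger inhibitor of growth:
Compound 1 `O=C(Nc1ccccc1O)C1CCc2ccccc2N1C(=O)c1ccccc1Cl`: 47400 nM
Compound 2 `O=C(Nc1ccccc1C(F)(F)F)C1CCc2ccccc2N1C(=O)c1cccc(Cl)c1`: 288 nM

Compound 2 holds the lower of the two numbers, and the gap to compound 1 lies beyond the scatter. Going by the values given here, it is therefore the stronger inhibitor of growth in this assay so far.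

Compound 3 `O=C(Nc1ccccc1C(F)(F)F)C1CCc2ccccc2N1C(=O)c1ccccc1Cl` has not yet been measured. It differs from compound 2 at one place, on a carbonyl carbon whose other neighbours are an amide-type nitrogen in a ring: 2-chlorophenyl in place of 3-chlorophenyl on a carbonyl carbon. In short, 2-chlorophenyl stands in place of 3-chlorophenyl.

Among the compounds with values here, no pair of measured compounds shows a change of this kind, so there is no precedent for the size of the step. The change keeps the same atoms, so a modest step is expected rather than a large one. Within the data shown here, its expected direction is toward a higher number, not far beyond the scatter, as compound 2 at 288 nM is the lower of only two values. The expected change is a 2.4-fold higher number from compound 2 to compound 3 (0.39 log units; beyond the scatter). Compound 3 is estimated at 700 nM, with an expected range from 150 nM to 4000 nM.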

Compound 3, concentration for 50% growth inhibition: 2530 nM
Estimate against measurement, compound 3: 3.6-fold (0.56 log units) below, within the range that was stated.
By their numbers in this assay, from the lowest: compound 2; then compound 3; then compound 1.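

In this assay, 2-chlorophenyl in place of 3-chlorophenyl on a carbonyl carbon gives an 8.8-fold higher number from compound 2 to compound 3 (0.94 log units; beyond the scatter), which shows that the same atoms, joined differently at this one place, can separate two compounds by more than the usual scatter. Going by these compounds alone, compound 3 also provides the first one-place comparison at the other end of the molecule: with 2-chlorophenyl held in common, trifluoromethyl in place of hydroxy on an aromatic carbon gives a 19-fold lower number from compound 1 to compound 3 (1.27 log units; beyond the scatter), so that this exchange moves the number further than the chlorine shift does. No measurement is at hand that would explain either step.

The compounds shown leave open whether the trifluoromethyl for hydroxy step would keep its size with 3-chlorophenyl on the carbonyl carbon, since the only pair that reads it carries 2-chlorophenyl. They also leave open how this assay would respond to a phenyl without chlorine or a methoxyphenyl on the carbonyl carbon, or to an amine or a nitrile in place of trifluoromethyl on the aromatic carbon.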